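Acid to Tetrazole in a Leukotriene Receptor Series

The source may hold more compounds than are shown below. What is called first, only, known or untested is meant among the compounds shown, and "the series" means these compounds.

Three compounds built on a shared core have been examined in an assay on isolated protein for inhibition of leukotriene B4 receptor 1 (Homo sapiens), tested at 10 uM; on this read-out higher numbers stand for more inhibition at the one concentration tested (going by the name of the read-out) and lower numbers for less inhibition. Compound 1 `C=CCc1cc(C(C)=O)c(O)cc1OCC#N` gives 20%, and compound 2 `CC(=O)c1cc(C(C)(C)C)c(OCCCCCC(C)(C)C#N)cc1O` gives 1%. Compound 3 `CCc1cc(C(C)=O)c(O)cc1OCCCC(C)(C)C(=O)O` gives 89%, the highest of the three numbers; its gap to compound 1 and its wider gap to compound 2 both lie beyond the usual scatter of repeated measurements, so the inhibition of compound 3 in this assay stands as the highest of the measured set.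

Compound 4 `CCc1cc(C(C)=O)c(O)cc1OCCCCCCc1nnn[nH]1` has not yet been measured. It differs from compound 3 in one place: 3-(1H-tetrazol-5-yl)propyl in place of 1-carboxy-1-methylethyl on a saturated chain carbon, three bonds along the chain from an oxygen on an aromatic ring. The rest of the molecule is unchanged. Within the data shown here, no measured pair in this set isolates this exchange, so no measured step can be drawn on directly.

The expectation for compound 4 rests on compound 3, whose reading of 89% is the only one in this set that comes with a 1-carboxy-1-methylethyl end, and the step of a number 14 percentage points lower from compound 3 to compound 4 (beyond the scatter) is expected to be modest and downward, perhaps no larger than the scatter. Compound 4 is therefore estimated at 75% in this assay, with a likely range from 45% to 95%.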

Compound 4, a percentage reported as inhibition, at one concentration (the size of the read-out at that concentration, not a potency): 91%
Compound 4: middle estimate off by 16 percentage points, on the low side; measured number inside the range.
By their numbers in this assay, from the lowest: compound 2; then compound 1; then compounds 3 and 4 (each within the scatter of the next).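

In this assay, putting 3-(1H-tetrazol-5-yl)propyl in place of 1-carboxy-1-methylethyl on a saturated chain carbon, three bonds along the chain from an oxygen on an aromatic ring, gives a number 2 percentage points higher from compound 3 to compound 4 (within the scatter). Among these compounds, this is the first step in the set between compounds that differ in one place, and it shows that a high reading at this position does not depend on the 1-carboxy-1-methylethyl end: a larger end carrying a five-membered aromatic ring with 4 hetero atoms reads alike in this one pair. Nothing measured here offers an explanation for why the two ends read alike.

Still open, going by these compounds, is whether other ends at this place would hold the reading, such as a methyl ester, an amine, or a tetrazole on a shorter chain. Compound 3 and compound 4 are also compared at one concentration only, so this pair cannot say whether their potencies would match across a full range of concentrations.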